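From 2-chlorophenyl to 3-chlorophenyl in compound 4

The source may report more compounds than this note shows. Statements on the series, on what has been measured and on what is new or still open speak of the compounds shown alone.

Compound 1 `Cc1ccc(-c2cc(-c3ccoc3)cc(-c3ccc(Cl)s3)n2)o1` gives 33400 nM
Compound 2 `Cc1ccc(-c2cc(-c3ccoc3)cc(-c3ccc(Cl)s3)n2)cc1` gives 25300 nM
Compound 3 `Clc1ccc(-c2cc(-c3ccoc3)cc(-c3ccccc3Cl)n2)s1` gives 16400 nM

All three values come from a functional assay on DU-145 cells (Homo sapiens) for cytotoxicity, read by ELISA, with a stated time of 4 days (on this read-out higher numbers stand for weaker inhibition and lower numbers for stronger inhibition), and the compounds differ in one group on a shared core. The steps reaching compound 3 are a 1.5-fold lower number from compound 2 to compound 3 (0.19 log units; within the scatter) and a 2.0-fold lower number from compound 1 to compound 3 (0.31 log units; beyond the scatter) so only compound 1 stands clearly apart from it.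

In compound 4 `Clc1cccc(-c2cc(-c3ccoc3)cc(-c3ccc(Cl)s3)n2)c1` the change 3-chlorophenyl in place of 2-chlorophenyl on an aromatic carbon is 3-chlorophenyl in place of 2-chlorophenyl on an aromatic carbon next to the ring nitrogen. Going by the values given here, no measured pair shows this exact swap. The nearest guides are swaps of whole groups at that same carbon. Besides the two steps above, these include a 1.3-fold lower number from compound 1 to compound 2 (0.12 log units; within the scatter) and all three were small. In this assay a step within the scatter is therefore expected, with no clear direction. The expected move is a 1.1-fold higher number from compound 3 to compound 4 (0.04 log units; within the scatter) and it would mean no real change. Compound 4 is estimated at 18000 nM with an expected range from 8000 nM to 38000 nM in this measurement.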

Compound 4, half-maximal inhibitory concentration: 23000 nM
Compound 4: the middle estimate sits 1.3-fold (0.11 log units) below what was measured; measured number inside the range.
By their numbers in this assay, from the lowest: compounds 3, 4, 2 and 1 (each within the scatter of the next, the first and the last beyond it).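

Moving the chlorine, so that 3-chlorophenyl replaces 2-chlorophenyl with the same atoms joined differently, gives a 1.4-fold higher number from compound 3 to compound 4 (0.15 log units; within the scatter) in this assay and so shows no real change at this carbon. Compound 4 also lies within the scatter of both other compounds, with a 1.1-fold lower number from compound 2 to compound 4 (0.04 log units; within the scatter) and a 1.5-fold lower number from compound 1 to compound 4 (0.16 log units; within the scatter) as its steps, so compound 1 stands clearly apart from compound 3 but not from compound 4. Nothing available here explains these small differences.

From the compounds shown here alone, all the groups compared at this carbon are aromatic rings of similar size, so the effect of a very different group, such as an amine or a carboxylic acid, remains open. Also open, going by these compounds, is whether 4-chlorophenyl would behave like the 2-chlorophenyl and 3-chlorophenyl groups.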